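Two Measured Compounds and an Expected Third

The compounds below may be only part of what the source reports. "The series", "measured", "known", "first", "only" and "open" are said of these compounds alone.

The series is read in a functional assay on PC-3 cells (Homo sapiens) for cytotoxicity, read by MTT assay, with a stated time of 48 h; a higher number here means a weaker inhibitor, a lower number a stronger inhibitor. Compound 1 `CC1=NN(C(=O)CN2CCN(C)CC2)C(c2ccccc2O)C1` gives 11800 nM there. Compound 2 `O=C(c1ccccc1)N1N=C(c2cc3ccccc3oc2=O)CC1c1ccccc1` gives 5870 nM in this assay; its number is the lower of the two, but the two values lie within the usual scatter of each other, so nothing separates the two compounds in strength on these data.

Compound 3 `CC(C)CNCC(=O)N1N=C(c2cc3ccccc3oc2=O)CC1c1ccccc1` is not yet measured in this assay. It differs from compound 2 in one place: (isobutylamino)methyl in place of phenyl on a carbonyl carbon. Within the data shown here, no step between measured compounds with a change of this kind is recorded, so the expectation rests on compound 2 alone. The author expects a small step from compound 2 to compound 3, a 1.2-fold higher number from compound 2 to compound 3 (0.08 log units; within the scatter), not beyond the scatter in either direction. Compound 3 is therefore estimated at 7000 nM in this assay, with a range from 2500 nM to 20000 nM.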

Compound 3, half-maximal inhibitory concentration: 1920 nM
The estimate for compound 3 lay 3.6-fold (0.56 log units) above the measured number, outside the stated range (below it).
By their numbers in this assay, from the lowest: compound 3; then compounds 2 and 1 (each within the scatter of the next).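

On the carbonyl carbon whose other neighbour is the amide-type nitrogen in a ring, the change from phenyl to (isobutylamino)methyl gives a 3.1-fold lower number from compound 2 to compound 3 (0.49 log units; beyond the scatter) in this assay. This shows that the number responds to the group at this position and that an aromatic ring there is not needed to keep the activity seen with compound 2. The two groups both count 6 heavy atoms, so the step goes with a change in the kind of group rather than in its heavy-atom count, and nothing available accounts for it.

The compounds shown leave open whether the step goes with the nitrogen of the chain or with the loss of the ring. An isobutoxymethyl group, with oxygen in place of that nitrogen, and a cyclohexyl group, a ring of carbon that is not aromatic, would each bear on that question.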